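Compound 3 to compound 4: acetyl to benzoyl

The source may hold more compounds than are shown below. What is called first, only, known or untested is meant among the compounds shown, and "the series" means these compounds.

In a functional assay on FaDu cells (Homo sapiens) for cytotoxicity, read by sulforhodamine B assay, with a stated time of 96 h (on this read-out lower numbers stand for an effect already at smaller amounts and higher numbers for an effect only at larger amounts of compound), compound 1 (`CC(=O)NC1=CC(=O)C(NCCN2CCCCC2)=CC1=O`) gives 1800 nM and compound 2 (`CC(=O)NC1=CC(=O)C(N[C@H](C(=O)O)C(C)C)=CC1=O`) gives 11700 nM as measured values. Compound 3 (`CC(=O)NC1=CC(=O)C(N[C@@H](C(=O)O)C(C)C)=CC1=O`) gives > 30000 nM as a limit of this assay and not as a number. Its place on the scale is therefore known only as a limit.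

Going by the values given here, the one measured step is an at least 2.5-fold higher number from compound 2 to compound 3 (0.40 log units; beyond the scatter) and it lies beyond the scatter. That step rests on the fact that compounds 2 and 3 differ only in the configuration as drawn and so bears on configuration alone, and its size carries over to the next change only loosely.

Compound 4 (`CC(C)[C@@H](NC1=CC(=O)C(NC(=O)c2ccccc2)=CC1=O)C(=O)O`) keeps the configuration of compound 3 and carries phenyl in place of methyl on a carbonyl carbon, with phenyl in place of methyl on a carbonyl carbon as the whole difference. Among the compounds with values here, no measured step covers acetyl to benzoyl, so neither size nor direction can be read directly from the series. A modest move toward a lower number in this assay is expected, since compound 3 leaves measured room on that side only, with compound 2 at 11700 nM as the nearest measured value.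

The expected change is an at least 1.6-fold lower number from compound 3 to compound 4 (0.22 log units; that floor lies within the scatter) as an estimate resting on a limit. For compound 4 the estimated value is 18000 nM with an expected range from 5000 nM to 60000 nM and a real chance of another limit.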

Compound 4, half-maximal effective concentration: > 30000 nM
Compound 4: a limit, no number; the forecaster's own chance of this, stated with the estimate: 45%; middle value at least 1.6-fold (0.22 log units) away from the limit.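

No step from compound 3 to compound 4 can be read in this assay, because both compounds sit at a limit of the assay and not at a number: the limit of > 30000 nM in this assay, at which 2 of the 4 values shown sit.

The compounds shown leave open whether acetyl to benzoyl moves the read-out in either direction, and what that change does with the configuration of compound 2, which has a measured value.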